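Phenyl in place of phenoxy: compound 4 awaits measurement

This account rests on a few compounds, and the source may have more. Where it says the series, first, only, none or still open, it means among the compounds named here.

In an ADME assay on microsomes from liver (Homo sapiens), read by LC-MS, using NADPH, with a stated time of 10 min, tested at 0.5 uM (a lower number here means that less of the compound is left, a higher number that more of the compound is left), compound 3 (`Cc1nc2cc(-c3cccc(Oc4ccccc4)c3)nn2c(-c2cc(F)c3c(c2C)CCCO3)c1C(OC(C)(C)C)C(=O)O`) gives 100%. Compound 1 (`Cc1ccc(-c2cc3nc(C)c(C(OC(C)(C)C)C(=O)O)c(-c4cc(F)c5c(c4C)CCCO5)n3n2)cc1`) gives 95%, which lies within the scatter of the value for compound 3. Compound 2 (`Cc1nc2cc(-c3cccc(OCc4ccccc4)c3)nn2c(-c2cc(F)c3c(c2C)CCCO3)c1C(OC(C)(C)C)C(=O)O`) gives 72%, which lies beyond the scatter below the value for compound 3.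

Compound 4 (`Cc1nc2cc(-c3cccc(-c4ccccc4)c3)nn2c(-c2cc(F)c3c(c2C)CCCO3)c1C(OC(C)(C)C)C(=O)O`) departs from compound 3 at a single place: phenyl in place of phenoxy on an aromatic carbon. The change is phenyl in place of phenoxy on an aromatic carbon, meta to a large group.

Going by the values given here, only one measured step bears on this change. It is a number 28 percentage points higher from compound 2 to compound 3 (beyond the scatter), with phenyl in place of benzyl on an oxygen on an aromatic ring. Among the compounds with values here, that step alters the same substituent, but it keeps the oxygen, so no measured step removes the oxygen directly. Within the data shown here, the nearest evidence for a substituent without that oxygen is compound 1 at 95%, although its aryl group differs from the one in compound 4. Compound 2 shows that this substituent can matter in this assay, so a fall cannot be ruled out.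

Expected, then, is a number 8 percentage points lower from compound 3 to compound 4 (within the scatter), a step not beyond the scatter. For compound 4 the estimated value is 92%, with an expected range from 75% to 100%.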

Compound 4, percent of the compound remaining: 86%
Estimate against measurement, compound 4: 6 percentage points above; the measured number falls inside the stated range.
By their numbers in this assay, from the lowest: compound 2; then compounds 4, 1 and 3 (each within the scatter of the next, the first and the last beyond it).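

Phenyl in place of phenoxy on an aromatic carbon gives a number 14 percentage points lower from compound 3 to compound 4 (beyond the scatter) in this assay and is the first direct test of losing the oxygen at this position, showing that the two aryl groups are not interchangeable there even though the earlier step from benzyl to phenyl had kept that oxygen. Phenyl in place of benzyloxy gives a number 14 percentage points higher from compound 2 to compound 4 (beyond the scatter) and, together with the earlier a number 28 percentage points higher from compound 2 to compound 3 (beyond the scatter), places the three substituents on this carbon apart from one another, with phenoxy highest, phenyl in the middle and benzyloxy lowest, while 3-phenylphenyl in place of 4-methylphenyl gives a number 9 percentage points lower from compound 1 to compound 4 (within the scatter) and so does not separate those two aryl groups. No measurement shown here accounts for this order among the three substituents.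

What the compounds shown leave open is how a smaller or non-aromatic group on this same aromatic carbon, such as an amine or a methoxy group, would stand in this assay against phenyl and phenoxy. They also leave open whether this order would persist if the tert-butoxy group on the acid side chain were replaced by a longer chain.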